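The compounds below may be only part of what the source reports. "The series", "measured", "known", "first", "only" and "open" are said of these compounds alone.

Compound 2 `Cc1cc(-c2ccccc2OCC2=NCCN2)sn1` carries 3-methyl-1,2-thiazol-5-yl where compound 1 `c1cncc(-c2ccccc2OCC2=NCCN2)c1` carries pyridin-3-yl. In a functional assay for activation of Alpha-1B adrenergic receptor (Homo sapiens), read by calcium flux (a lower number here means that less compound is needed, a higher number that more compound is needed for the effect), compound 1 gives 79.4 nM. In this assay compound 2 reaches only a limit, < 100000 nM, so its standing on the numbers is bounded on one side alone. The step that the limit leaves unreadable from compound 1 to compound 2 therefore has no readable size, and the limit of < 100000 nM in this assay, at which 1 of the 2 values shown sits, is all that the measurements offer. Compound 3 `Cn1nccc1-c1ccccc1OCC1=NCCN1` differs from compound 2 by 1-methyl-1H-pyrazol-5-yl in place of 3-methyl-1,2-thiazol-5-yl on an aromatic carbon. Within the data shown here, no measured step bears on this change, so the expectation rests on the limit of compound 2 alone. Compound 3 is estimated at 3000 nM, in a range from 150 nM to 60000 nM, an expected step that the limit leaves unreadable from compound 2 to compound 3.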

Compound 3, half-maximal effective concentration: < 100000 nM
Compound 3 was reported as a limit (the forecaster's own chance of this, stated with the estimate: 35%); the middle value does not contradict the limit.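

Compound 3 gives only a limit, so no new step can be read against compound 1 or compound 2: the limit of < 100000 nM in this assay, at which 2 of the 3 values shown sit.

The compounds shown leave open how far compound 2 and compound 3 lie from compound 1 in this assay, and whether they differ from each other.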